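Formyl for 2-oxopropoxy on a benzyloxy-coumarin scaffold

This account rests on a few compounds, and the source may have more. Where it says the series, first, only, none or still open, it means among the compounds named here.

Measured compounds:
compound 1, `CCCOc1cc(=O)oc2cc(OCc3ccccc3)ccc12`, 575 nM
compound 2, `CC(=O)COc1cc(=O)oc2cc(OCc3cccc(Cl)c3)ccc12`, 26.9 nM

Both compounds were tested in an assay on isolated protein (strain Sprague-Dawley) for inhibition of Amine oxidase [flavin-containing] B (Rattus norvegicus), read by spectrophotometry, with a stated time of 5 min; a higher number here means a weaker inhibitor, a lower number a stronger inhibitor. Compound 1, which carries a propoxy group and an unsubstituted benzyloxy group on the shared core, gives 575 nM. Compound 2, with a 2-oxopropoxy group and a chlorine on the benzyloxy ring, gives 26.9 nM. Of the two numbers, compound 2 stands lowest, and its gap to compound 1 lies beyond the usual scatter; the two compounds differ in two places, so nothing can be said about which change carries the difference.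

Compound 3, `O=Cc1cc(=O)oc2cc(OCc3cccc(Cl)c3)ccc12`, is not yet measured. It keeps the chlorinated benzyloxy group of compound 2 and differs from it in one place: formyl in place of 2-oxopropoxy on an aromatic carbon. Going by the values given here, no comparable step between measured compounds is available, so the expectation rests on compound 2 alone. The step from compound 2 to compound 3 is expected to be small, a 2.2-fold higher number from compound 2 to compound 3 (0.35 log units; beyond the scatter), most likely a modest weakening that may not exceed the scatter. For compound 3 the estimate in this assay is 60 nM, with a range from 10 nM to 400 nM.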

Compound 3, half-maximal inhibitory concentration: 52.5 nM
For compound 3 the middle estimate is 1.1-fold (0.06 log units) above the measured one; the range from low to high includes it.
By their numbers in this assay, from the lowest: compounds 2 and 3 (each within the scatter of the next); then compound 1.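

In this assay, replacing 2-oxopropoxy with formyl on this aromatic carbon, opposite the ring oxygen, gives a 2.0-fold higher number from compound 2 to compound 3 (0.29 log units; within the scatter), so the two compounds cannot be told apart in this measurement. Going by these compounds alone, this is the first change that can be read in one place, and it shows that, with the chlorinated benzyloxy group held constant, a substituent of 5 heavy atoms and 2 hydrogen-bond acceptors can give way to one of 2 heavy atoms and 1 hydrogen-bond acceptor without a difference beyond the scatter. No measured evidence is available that explains this result.

The compounds shown still do not separate the contributions of the propoxy-to-2-oxopropoxy change and the chlorine to the gap between compound 1 and compound 2, since those compounds differ in two places. From the compounds shown here alone, it also remains open how an amine, a carboxylic acid or a longer chain would read at this position, and whether formyl and 2-oxopropoxy would remain as close with an unsubstituted benzyloxy group.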